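The source may report more compounds than this note shows. Statements on the series, on what has been measured and on what is new or still open speak of the compounds shown alone.

Three compounds sharing one core have been measured in a functional assay, read by spectrophotometry, with a stated time of 30 min; a higher number here means a weaker inhibitor, a lower number a stronger inhibitor:

Compound 1 `Cc1ccc2[nH]c(=O)c(/C=N/Nc3ccccc3)cc2c1` gives 62400 nM.
Compound 2 `Cc1ccc2[nH]c(=O)c(/C=N/NC(=O)CS(N)(=O)=O)cc2c1` gives 3350000 nM.
Compound 3 `Cc1ccc2[nH]c(=O)c(/C=N/Nc3ccc([N+](=O)[O-])cc3)cc2c1` gives 109000 nM.

Compound 1 stands at the lowest number of the three. Compound 3 is nearest to it, with a 1.7-fold higher number from compound 1 to compound 3 (0.24 log units; within the scatter), and compound 2 is furthest, with a 54-fold higher number from compound 1 to compound 2 (1.73 log units; beyond the scatter). Compound 4 `Cc1ccc2[nH]c(=O)c(/C=N/CCO)cc2c1` has not yet been measured. It differs from compound 1 in one place: 2-hydroxyethyl in place of anilino on a double-bonded nitrogen. Going by the values given here, of the measured steps, only the one to compound 2 bears on this change, since there too the phenyl on the amine nitrogen gave way to a group with no ring, and the number rose by a 54-fold higher number from compound 1 to compound 2 (1.73 log units; beyond the scatter). The step to compound 3, which keeps the ring and only adds nitro, was a 1.7-fold higher number from compound 1 to compound 3 (0.24 log units; within the scatter) and says little about removing the ring. Since compound 4 also gives up the ring for a short chain, a step toward a higher number, beyond the scatter, is expected in this assay, and the expected step is a 9.6-fold higher number from compound 1 to compound 4 (0.98 log units; beyond the scatter). Compound 4 is therefore estimated at 600000 nM, with a range from 150000 nM to 3000000 nM.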

Compound 4, half-maximal inhibitory concentration: 498000 nM
Beside the measured number, compound 4's estimate is 1.2-fold (0.08 log units) above it, within the range that was stated.
By their numbers in this assay, from the lowest: compounds 1 and 3 (each within the scatter of the next); then compound 4; then compound 2.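

In this assay the change to 2-hydroxyethyl brings an 8.0-fold higher number from compound 1 to compound 4 (0.90 log units; beyond the scatter) and so gives a second replacement without a ring that raises the number from that of compound 1. This step comes with a smaller group but with the same hydrogen-bond donor and acceptor counts in the group that leaves and the group that enters, so those counts alone do not separate compound 1 from compound 4. Nothing measured here gives a cause for the step. The compounds shown leave open what the hydroxyl contributes, which a plain ethyl group or a longer chain ending in hydroxyl could test, and how an amine or a carboxylic acid on the chain would behave. They also leave open whether the ring or the anilino nitrogen matters more, which a benzyl group could help separate.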